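Chloro for nitro on the pendant aryl ring of a pyrazole aldehyde

This account rests on a few compounds, and the source may have more. Where it says the series, first, only, none or still open, it means among the compounds named here.

Compound 1 `O=Cc1cn(-c2ccccc2)nc1-c1ccc([N+](=O)[O-])cc1`: 86%
Compound 2 `O=Cc1cn(-c2ccccc2)nc1-c1ccccc1O`: 92%
Compound 3 `O=Cc1cn(-c2ccccc2)nc1-c1cccc([N+](=O)[O-])c1`: 89%

Of the compounds shown here, three sharing the same core have been measured in a functional assay on MCF7 cells (Homo sapiens) for antiproliferative activity, read by MTT assay, with a stated time of 24 h, tested at 0.01 ug/mL; on this read-out lower numbers stand for a stronger effect and higher numbers for a weaker effect at the one concentration tested. Compound 1 gives 86%, which is the lowest of the three numbers, but its neighbours sit close: compound 3 gives 89% and compound 2 gives 92%, and both gaps to compound 1 fall within the usual scatter of this assay. Among the measured compounds shown here, no difference between any pair of these measured compounds is therefore large enough to speak of an order among them; the three simply cluster together at a weak effect.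

The next compound, compound 4 `O=Cc1cn(-c2ccccc2)nc1-c1ccc(Cl)cc1`, has not yet been tested. It differs from compound 1 as follows: chloro in place of nitro on an aromatic carbon. The change is a swap of one substituent for another on the same aromatic carbon, para to a large group, with nitro leaving and chloro entering.

For the measured compounds named here, nothing measured so far separates any two compounds beyond the scatter, so the step from compound 1 to compound 4 is expected to be small, a number 2 percentage points higher from compound 1 to compound 4 (within the scatter), without a clear direction. Compound 4 is accordingly estimated at 88% in this assay, within a range from 78% to 98%.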

Compound 4, a percentage reported as activity, at one concentration (the size of the read-out at that concentration, not a potency): 98%
The estimate for compound 4 lay 10 percentage points below the measured number; measured number inside the range.
By their numbers in this assay, from the lowest: compounds 1, 3, 2 and 4 (each within the scatter of the next, the first and the last beyond it).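

In this assay, among the compounds shown here, chloro in place of nitro on the aromatic carbon para to a large group gives a number 12 percentage points higher from compound 1 to compound 4 (beyond the scatter) and forms the only step here between compounds that differ in one place. It shows that this position is not indifferent to its substituent: at the one concentration tested, the effect is weaker with chloro than with nitro, something the close cluster of the first three compounds could not reveal. Nothing available explains this step, so the data give its size and direction but not its cause.

The compounds shown leave open whether nitro stands out at this position or chloro is the unfavourable group, since a single swap cannot separate the loss of one from the gain of the other, and an amine, a methoxy group or a plain hydrogen on the same carbon would help to settle this. They also leave open whether the step would hold at other concentrations or with other groups on the rest of the shared core, as only one concentration, one cell line and one such pair are shown.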